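This account rests on a few compounds, and the source may have more. Where it says the series, first, only, none or still open, it means among the compounds named here.

Of the compounds shown here, three sharing one core have been tested in a functional assay on L1210 cells (Mus musculus), with a stated time of 12 days; on this read-out higher numbers stand for higher potency (the scale is a negative logarithm) and lower numbers for lower potency. Compound 1 `CCOC(COC(N)=O)C1=C(N2CC2)C(=O)C(C)=C(N2CC2)C1=O` gives 5.22, compound 2 `CC1=C(N2CC2)C(=O)C(C2CCCCC2)=C(N2CC2)C1=O` gives 5.39, and compound 3 `CC1=C(N2CC2)C(=O)C(C(C)COC(N)=O)=C(N2CC2)C1=O` gives 5.71, the highest of the three, with rises of a number 0.49 log units higher from compound 1 to compound 3 (beyond the scatter) and a number 0.32 log units higher from compound 2 to compound 3 (beyond the scatter). Within the data shown here, compound 4 `COCCOC(COC(N)=O)C1=C(N2CC2)C(=O)C(C)=C(N2CC2)C1=O` alters compound 3 in one place: 2-methoxyethoxy in place of methyl on a saturated chain carbon bound to a double-bonded ring carbon and a saturated chain carbon Only the step from compound 1 bears on this change, because it too exchanged ethoxy for methyl on the same saturated chain carbon and gave a number 0.49 log units higher from compound 1 to compound 3 (beyond the scatter). Returning to an oxygen-linked chain, now a longer one, is therefore expected to lower potency by roughly that amount, a number 0.51 log units lower from compound 3 to compound 4 (beyond the scatter). Compound 4 is thus estimated at 5.2, with a likely range from 4.8 to 5.6.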

Compound 4, logarithm of the reciprocal of the active concentration, log(1/C): 5.39
Compound 4: the middle estimate sits 0.19 log units below what was measured; measured number inside the range.
By their numbers in this assay, from the lowest: compounds 1, 2 and 4 (each within the scatter of the next); then compound 3.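

In this assay, 2-methoxyethoxy in place of methyl on this saturated chain carbon gives a number 0.32 log units lower from compound 3 to compound 4 (beyond the scatter) and so, like the ethoxy of compound 1, falls short of methyl. Adding methoxy in place of hydrogen to the ethoxy chain gives a number 0.17 log units higher from compound 1 to compound 4 (within the scatter) and so no change that can be told apart from scatter. Nothing measured here says what lies behind these numbers. Going by these compounds, whether methyl is the best group at this carbon stays open: hydrogen, ethyl or an amine there could land above or below compound 3 in potency.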